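Methyl for Methoxy on a Tethered Hydroxyacyl Side Chain

This account rests on a few compounds, and the source may have more. Where it says the series, first, only, none or still open, it means among the compounds named here.

Measured compounds:
compound 1 `O=C(NCc1cc(Cl)ccc1-n1cnnn1)[C@@H]1[C@H]2C[C@H]2CN1C(=O)[C@H](O)CC1CC1` — 1400 nM
compound 2 `COC(C)(C)[C@@H](O)C(=O)N1N=CC[C@H]1C(=O)NCc1cc(Cl)ccc1-n1cnnn1` — 3700 nM
compound 3 `CC(C)(C)[C@@H](O)C(=O)N1OCC[C@H]1C(=O)NCc1cc(Cl)ccc1-n1cnnn1` — 1600 nM

Three compounds have been run in a functional assay on a cell-free system (plasma, Homo sapiens), with a stated time of 3 min (on this read-out higher numbers stand for weaker inhibition and lower numbers for stronger inhibition), so far. Compound 1 gives 1400 nM, compound 3 gives 1600 nM, and compound 2 gives 3700 nM, the highest of the three numbers and therefore the weakest inhibition shown. Its gap to compound 3 and its wider gap to compound 1 both lie beyond the scatter, so compound 2 stands apart from the other two on this read-out. Within the data shown here, no single-point step between the measured compounds is available, so the three values can only be read as they stand.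

Compound 4 `CC(C)(C)[C@@H](O)C(=O)N1N=CC[C@H]1C(=O)NCc1cc(Cl)ccc1-n1cnnn1` has not been measured. It is derived from compound 2 by one change: methyl in place of methoxy on a saturated chain carbon bound to three saturated chain carbons. The remainder of the molecule, including the shared core of compound 2, is untouched.

Among the measured compounds shown here, with no measured step of this kind to lean on, the expected change from compound 2 to compound 4 is small, at most a modest move toward stronger inhibition, estimated as a 1.7-fold lower number from compound 2 to compound 4 (0.23 log units; within the scatter). Compound 4 is therefore estimated at 2200 nM, with a range from 900 nM to 5500 nM.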

Compound 4, half-maximal inhibitory concentration: 1400 nM
For compound 4 the middle estimate is 1.6-fold (0.20 log units) above the measured one; the measured number falls inside the stated range.
By their numbers in this assay, from the lowest: compounds 1, 4 and 3 (each within the scatter of the next); then compound 2.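

In this assay, putting methyl in place of methoxy on a saturated chain carbon bound to three saturated chain carbons gives a 2.6-fold lower number from compound 2 to compound 4 (0.42 log units; beyond the scatter). Among these compounds, this is the first single-place step in the set, and it shows that this position is not indifferent to the change: on the core shared by these two compounds, going from 1-methoxy-1-methylethyl to tert-butyl is enough to move the number beyond the scatter. No measurement shown here accounts for the size of this step.

The compounds shown leave open how a hydroxyl, an amine or an ethyl group at this place on the chain would read. They also leave open whether methoxy in place of methyl on the core of compound 3 would raise the number there as well.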